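Anilinopyrimidine ureas: swapping the anilino aryl group

This account rests on a few compounds, and the source may have more. Where it says the series, first, only, none or still open, it means among the compounds named here.

Measured so far:
compound 1 `COc1ccc(F)cc1Nc1cc(NC(=O)Nc2c(Cl)cccc2Cl)ncn1` — 78%
compound 2 `COc1cc(NC(=O)Nc2cc(Nc3ccc(C)c(C)c3)ncn2)cc(OC)c1` — 45.7%
compound 3 `COc1ccc(Br)cc1Nc1cc(NC(=O)Nc2c(Cl)cccc2Cl)ncn1` — 53%

Compound 2 gives the lowest of the three numbers in a functional assay on HCC827 cells (Homo sapiens) for inhibition, read by MTT assay, with a stated time of 48 h, tested at 10 uM; on this read-out lower numbers stand for less inhibition and higher numbers for more inhibition at the one concentration tested (going by the name of the read-out); compound 3 sits within the scatter of it, while compound 1 lies beyond the scatter above it. Compound 4 `COc1cc(NC(=O)Nc2cc(Nc3ccc(Br)cc3OC)ncn2)cc(OC)c1` carries the change (4-bromo-2-methoxyphenyl in place of 3,4-dimethylphenyl on a nitrogen on an aromatic ring). Going by the values given here, the only measured step, a number 25 percentage points lower from compound 1 to compound 3 (beyond the scatter), concerns the halogen on the anilino aryl group and not the exchange made here, so no step bears directly on it. The entering group of compound 4 is shared with compound 3, and compound 3 gives 53%. Among the compounds with values here, with no direct precedent, the step from compound 2 to compound 4 in this assay is expected to stay within the scatter, a number 2.3 percentage points higher from compound 2 to compound 4 (within the scatter). Compound 4 is therefore estimated at 48%, between 28% and 68%.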

Compound 4, a percentage reported as inhibition, at one concentration (the size of the read-out at that concentration, not a potency): 57.7%
For compound 4 the middle estimate is 9.7 percentage points below the measured one; the range from low to high includes it.
By their numbers in this assay, from the lowest: compounds 2, 3 and 4 (each within the scatter of the next, the first and the last beyond it); then compound 1.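

In this assay the change to 4-bromo-2-methoxyphenyl in place of 3,4-dimethylphenyl on a nitrogen on an aromatic ring gives a number 12 percentage points higher from compound 2 to compound 4 (beyond the scatter) as the step at this position. The read-out therefore responds to an exchange of the whole aryl group, and not only to a halogen swap on it. No evidence at hand accounts for this step.

Going by these compounds alone, the single exchange does not separate the bromo group from the methoxy group. From the compounds shown here alone, how an aminomethyl group or a carboxylic acid on this aryl group would fare remains open.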